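A Methoxy Added to the Phenyl Ring of Compound 2

The source may hold more compounds than are shown below. What is called first, only, known or untested is meant among the compounds shown, and "the series" means these compounds.

In a functional assay on MCF7 cells (Homo sapiens) for inhibition, read by MTT assay, with a stated time of 48 h (a higher number here means a weaker inhibitor of growth, a lower number a stronger inhibitor of growth), compound 1 (`Cn1cc(C2CC(c3ccccc3)=NN2C(=O)c2cccnc2)c2cc(Br)ccc21`) gives 1520 nM and compound 2 (`COc1ccc2c(c1)c(C1CC(c3ccccc3)=NN1C(=O)c1cccnc1)cn2C`) gives 1160 nM as its result. These two numbers lie within the scatter of each other, so compound 2 stands level with compound 1 on the evidence so far. Within the data shown here, the only measured step is a 1.3-fold lower number from compound 1 to compound 2 (0.12 log units; within the scatter) and it comes from methoxy in place of bromo on an aromatic carbon. Compound 3 (`COc1cccc(C2=NN(C(=O)c3cccnc3)C(c3cn(C)c4ccc(OC)cc34)C2)c1`) differs from compound 2 by methoxy in place of hydrogen on an aromatic carbon and so turns phenyl to 3-methoxyphenyl. Among the measured compounds shown here, the measured step lies at a different place on the shared core, and no measured compound carries a group on this phenyl ring. It therefore offers only weak guidance, and no step beyond the scatter is expected in this assay in either direction. The expected change is a 1.1-fold lower number from compound 2 to compound 3 (0.04 log units; within the scatter) and this estimate stays small. For compound 3 the estimated value is 1050 nM with an expected range from 420 nM to 2600 nM in this measurement.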

Compound 3, concentration for 50% growth inhibition: 810 nM
Estimate against measurement, compound 3: 1.3-fold (0.11 log units) above; the measured number falls inside the stated range.
By their numbers in this assay, from the lowest: compounds 3, 2 and 1 (each within the scatter of the next).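

Among these compounds, the phenyl ring had carried no substituent in the earlier compounds, and compound 3 gives the first measured reading at this position. In this assay, among the compounds shown here, methoxy in place of hydrogen on this aromatic carbon gives a 1.4-fold lower number from compound 2 to compound 3 (0.16 log units; within the scatter), so 3-methoxyphenyl stands level with phenyl in this pair, and the added methoxy produces no step that can be told from the scatter. Like the earlier change of bromo to methoxy, a 1.3-fold lower number from compound 1 to compound 2 (0.12 log units; within the scatter), this step stays within the scatter, so neither of the two places changed so far has yet shown a clear effect on the number, and nothing available explains this result.

The compounds shown leave open whether a different group on this same aromatic carbon, such as an amine, a carboxylic acid or a longer chain like butoxy, would give a step beyond the scatter. For the compounds shown here, they also leave open whether any change at this position can separate one compound from another in this assay, since a single methoxy is the only group seen here so far.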